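Sulfonamide nitrogen substituents and tracheal maximal response

The compounds below may be only part of what the source reports. "The series", "measured", "known", "first", "only" and "open" are said of these compounds alone.

Measured compounds:
compound 1 `CC1(C)C=C(n2ccccc2=O)c2cc(S(=O)(=O)N=[N+]=[N-])ccc2O1`: 77.2%
compound 2 `CC1(C)C=C(n2ccccc2=O)c2cc(S(=O)(=O)NCc3ccccc3)ccc2O1`: 77.5%
compound 3 `COc1ccc(NS(=O)(=O)c2ccc3c(c2)C(n2ccccc2=O)=CC(C)(C)O3)cc1`: 84.2%

All three share one core and differ only at the sulfonyl sulfur or the sulfonamide nitrogen. In a functional assay on the whole organism (trachea) with Rattus norvegicus as the target (a higher number here means a larger maximal response, a lower number a smaller maximal response), compound 3 gives the largest of the three numbers, but this separates it from nothing: the gap a number 6.7 percentage points higher from compound 2 to compound 3 (within the scatter) and the gap a number 7 percentage points higher from compound 1 to compound 3 (within the scatter) are both within the scatter, as is a number 0.3 percentage points higher from compound 1 to compound 2 (within the scatter). Within the data shown here, the series so far shows no substituent at this position that moves the maximal response beyond repeat variation.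

Compound 4 `CC1(C)C=C(n2ccccc2=O)c2cc(S(=O)(=O)NC(=O)Nc3ccccc3)ccc2O1` is the next member. Its change from compound 3 is phenylcarbamoyl in place of 4-methoxyphenyl on a sulfonamide nitrogen. The step that bears on it most directly is a number 6.7 percentage points higher from compound 2 to compound 3 (within the scatter), which also swapped the group on the sulfonamide nitrogen and stayed within the scatter; the two steps from compound 1, which rebuilt the sulfonyl substituent entirely, were likewise within the scatter. On that basis no step beyond the scatter is expected in this assay, in either direction, with the estimated step of a number 4.2 percentage points lower from compound 3 to compound 4 (within the scatter). Compound 4 is therefore expected to give about 80%, in the range 68% to 92%.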

Compound 4, largest response reached (Emax), in percent of the reference or control that the assay uses: 99.5%
The estimate for compound 4 lay 19.5 percentage points below the measured number; the whole stated range lies below it.
By their numbers in this assay, from the lowest: compounds 1, 2 and 3 (each within the scatter of the next); then compound 4.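

In this assay, the substituent on the sulfonamide nitrogen now proves able to move the maximal response beyond repeat variation: phenylcarbamoyl gives a number 15.3 percentage points higher from compound 3 to compound 4 (beyond the scatter), and the comparisons with the other two compounds give a number 22 percentage points higher from compound 2 to compound 4 (beyond the scatter) and a number 22.3 percentage points higher from compound 1 to compound 4 (beyond the scatter). Compound 4 is thus the only one of the four set apart from all the others, and since 4-methoxyphenyl and phenylcarbamoyl each carry a six-membered aromatic ring of carbon only, that ring alone does not distinguish them; the entering group differs in having a hydrogen-bond donor and a double bond outside aromatic rings. Nothing available on the series accounts for the step, so it stands as an observation only.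

The compounds shown do not separate the contribution of the carbonyl, the added nitrogen and the phenyl ring within phenylcarbamoyl, a question that an acetyl or ethylcarbamoyl group on the sulfonamide nitrogen would address. They also leave open whether the higher maximal response persists when the phenyl ring of phenylcarbamoyl carries a methoxy group or a chlorine.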